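Carbamoyl in Place of Hydroxymethyl: Expected Cytotoxicity

The compounds below may be only part of what the source reports. "The series", "measured", "known", "first", "only" and "open" are said of these compounds alone.

Compound 1 `CC(C)C1=CC[C@H](CO)[C@@]12C=CC(=O)CC2`: > 90000 nM
Compound 2 `C=C1CC[C@H](C(=O)OCC)[C@@]12C=CC(=O)CC2`: > 90000 nM

In an ADME assay on BJ cells (Homo sapiens) for cytotoxicity, with a stated time of 72 h (on this read-out higher numbers stand for an effect only at larger amounts of compound and lower numbers for an effect already at smaller amounts), compound 1 gives > 90000 nM, which is a limit of the assay and not a measured number. Compound 2 likewise reaches only a limit, > 90000 nM. Both values shown therefore lie at the limit of > 90000 nM in this assay, at which 2 of the 2 values shown sit. Compound 3 `CC(C)C1=CC[C@H](C(N)=O)[C@@]12C=CC(=O)CC2` is not yet measured; it differs from compound 1 by carbamoyl in place of hydroxymethyl on a saturated ring carbon. Among the compounds with values here, no measured step of this kind exists, so the expected change is none beyond the usual scatter, giving an estimated step that the limit leaves unreadable from compound 1 to compound 3. For compound 3 the estimate in this assay is 100000 nM, between 40000 nM and 300000 nM, most likely again reported only as a limit.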

Compound 3, half-maximal effective concentration: > 90000 nM
Compound 3: a limit, no number; the forecaster's own chance of this, stated with the estimate: 85%; the middle value lies beyond the limit too.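

Compound 1 and compound 3 each give only a limit, so carbamoyl in place of hydroxymethyl yields no readable step: the limit of > 90000 nM in this assay, at which 3 of the 3 values shown sit. The compounds shown leave open which change to the shared core, if any, would give a measured number.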